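The source may hold more compounds than are shown below. What is called first, only, known or untested is meant among the compounds shown, and "the series" means these compounds.

Compound 1 `Cc1ccc(CO/N=C/c2c(C)nn(C)c2Oc2ccc(Cl)cc2)cc1` gives 50% in a functional assay on A549 cells (Homo sapiens) for antiproliferative activity, tested at 1 uM (a lower number here means less inhibition, a higher number more inhibition at the concentration tested (going by the name of the read-out)), the highest of the three numbers, though compound 3 `COC(=O)c1ccc(CO/N=C/c2c(C)nn(C)c2Oc2ccc(Cl)cc2)cc1` with 49.9% and compound 2 `CCOC(=O)c1ccc(CO/N=C/c2c(C)nn(C)c2Oc2ccc(Cl)cc2)cc1` with 48.2% both sit within the scatter of it, as a number 0.1 percentage points lower from compound 1 to compound 3 (within the scatter) and a number 1.8 percentage points lower from compound 1 to compound 2 (within the scatter) show. Compound 4 `Cc1ccc(CO/N=C/c2c(C)nn(C)c2Oc2ccccc2)cc1` is the unmeasured compound, differing from compound 1 by hydrogen in place of chloro on an aromatic carbon. Going by the values given here, none of the measured steps touches the chloro: a number 1.8 percentage points lower from compound 1 to compound 2 (within the scatter), a number 0.1 percentage points lower from compound 1 to compound 3 (within the scatter) and a number 1.7 percentage points higher from compound 2 to compound 3 (within the scatter) all concern methyl and ester groups and stay within the scatter. The data therefore give no direct guide to this change; the step of a number 6 percentage points lower from compound 1 to compound 4 (within the scatter) is expected to be small, with a modest lean toward less inhibition. Compound 4 is estimated at 44%, in a range from 25% to 62%.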

Compound 4, a percentage reported as inhibition, at one concentration (the size of the read-out at that concentration, not a potency): 29.1%
Compound 4: middle estimate off by 14.9 percentage points, on the high side; measured number inside the range.
By their numbers in this assay, from the lowest: compound 4; then compounds 2, 3 and 1 (each within the scatter of the next).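

In this assay, going by these compounds alone, the place on the six-membered aromatic ring of carbon only, para to a large group, proves sensitive where the methyl and ester changes were not: going from 4-chlorophenoxy to phenoxy gives a number 20.9 percentage points lower from compound 1 to compound 4 (beyond the scatter), the only step here beyond the scatter. Nothing at hand explains this drop.

Going by these compounds, whether a fluoro, a methoxy or an amine at this place would keep the number of compound 1 remains open, as does whether removing chloro from compound 2 or compound 3 would give a similar step.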